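The source may report more compounds than this note shows. Statements on the series, on what has been measured and on what is new or still open speak of the compounds shown alone.

Compound 1 `COC(=O)c1cc(-c2cccc(NC(=O)c3ccc(/C=C/C(=O)c4cccc(Cl)c4)cc3)c2)on1` — > 2.5 ug/mL
Compound 2 `COC(=O)c1cc(-c2cccc(NC(=O)c3ccc(/C=C/C(=O)c4ccc(C)c([N+](=O)[O-])c4)cc3)c2)on1` — > 80 ug/mL
Compound 3 `COC(=O)c1cc(-c2cccc(NC(=O)c3ccc(/C=C/C(=O)c4ccc(O)cc4)cc3)c2)on1` — "not determined" (no result reported)

Three compounds sharing one core were tested in an ADME assay on Vero cells (Chlorocebus sabaeus) for cytotoxicity, read by MTT assay, with a stated time of 72 h; a lower number here means that less compound is tolerated, a higher number that more compound is tolerated. In this assay compound 1 gives only a limit, > 2.5 ug/mL, which is the limit of > 2.5 ug/mL in this assay, at which 1 of the 3 values shown sits. Compound 2 likewise gives only a limit, > 80 ug/mL, which is the limit of > 80 ug/mL in this assay, at which 1 of the 3 values shown sits. The step that the two limits leave unreadable from compound 1 to compound 2 cannot be read as a size, since both ends are limits. Compound 3 has no number in this assay: its entry reads "not determined" (no result reported), so it stands nowhere on the scale. The two other values shown, those of compound 1 and compound 2, are themselves limits.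

Compound 4 `COC(=O)c1cc(-c2cccc(NC(=O)c3ccc(/C=C/C(=O)c4ccc([N+](=O)[O-])cc4)cc3)c2)on1` differs from compound 3 by nitro in place of hydroxy on an aromatic carbon. No measured step bears directly on this change: the only step shown, from compound 1 to compound 2, is unreadable, and compound 3 has no value to step from. What remains is that compound 2, which also carries a nitro group, reached the higher limit, while compound 1, without one, is known only from the lower limit.

For compound 4 in this assay, a value around 40 ug/mL is expected, within a range from 5 ug/mL to 100 ug/mL, and it may well again be reported only as a limit.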

Compound 4, half-maximal cytotoxic concentration: > 20 ug/mL
Compound 4: only a limit was reported (the forecaster's own chance of this, stated with the estimate: 60%); the middle value is on the limit's open side.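

In this assay compound 4 gives only a limit, > 20 ug/mL. Within the data shown here, compound 1, compound 2 and compound 4 all stand as limits, so no step among them can be read. The compounds shown leave open how much of each one the cells actually tolerate, and whether changing the aromatic group on the carbonyl alters that tolerance at all.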